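Removing the Bromoacrylamide from a Thiazolotriazole Aniline

The source may hold more compounds than are shown below. What is called first, only, known or untested is meant among the compounds shown, and "the series" means these compounds.

Measured so far in a functional assay on CCRF-CEM cells (Homo sapiens) for inhibition, read by cell counting, with a stated time of 3 days; a higher number here means a weaker inhibitor, a lower number a stronger inhibitor:
- compound 1, `Nc1cccc(-c2cn3nc(-c4ccc(Cl)cc4)sc3n2)c1`: > 250000 nM
- compound 2, `Nc1cccc(-c2cn3nc(-c4ccccc4)sc3n2)c1`: 33000 nM
- compound 3, `C=C(Br)C(=O)Nc1cccc(-c2cn3nc(-c4ccc(OC)cc4)sc3n2)c1`: 1200 nM

The value for compound 1 is a limit of this assay, not a number; it is the one described by the limit of > 250000 nM in this assay, at which 1 of the 3 values shown sits. Between compounds 1 and 2 the change is an at least 7.5-fold lower number from compound 1 to compound 2 (0.87 log units; beyond the scatter). Compound 3 stands lowest of the two numbers given, with compound 2 nearest at a higher number, and the gap between them lies beyond the usual scatter.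

Compound 4, `COc1ccc(-c2nn3cc(-c4cccc(N)c4)nc3s2)cc1`, differs from compound 3 in one place: hydrogen in place of (1-bromoethenyl)carbonyl on a nitrogen on an aromatic ring. Among the measured compounds shown here, no measured step covers this change; the only measured step concerns a chloro on a different ring. Compounds 1 and 2 do carry the same free amino group as compound 4, and compound 2, with a phenyl rather than methoxyphenyl, gives 33000 nM in this assay. Compound 4 is therefore expected to give a markedly higher number than compound 3, estimated as a 25-fold higher number from compound 3 to compound 4 (1.40 log units; beyond the scatter). For compound 4 the estimate in this assay is 30000 nM, with a range from 6000 nM to 150000 nM.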

Compound 4, half-maximal inhibitory concentration: >= 250000 nM
Compound 4: a limit, no number (the forecaster's own chance of this, stated with the estimate: 15%); middle value at least 8.3-fold (0.92 log units) away from the limit.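

In this assay the value for compound 4 is a limit and not a number: the limit of >= 250000 nM in this assay, at which 1 of the 4 values shown sits.

The step can still be read. Among the compounds shown here, putting hydrogen in place of (1-bromoethenyl)carbonyl on the nitrogen gives an at least 200-fold higher number from compound 3 to compound 4 (2.31 log units; beyond the scatter), so within this pair the lower number depends on that group, which no earlier pair could isolate. Among the free amino compounds, methoxy in place of hydrogen on an aromatic carbon gives an at least 7.5-fold higher number from compound 2 to compound 4 (0.87 log units; beyond the scatter), while the two limits leave the step from chloro to methoxy unreadable.

The compounds shown leave open how much of the (1-bromoethenyl)carbonyl group is needed, for instance whether a plain acetyl or propenoyl group on that nitrogen would keep a low number. Also open, from the compounds shown here alone, is what the same group would do on the phenyl and chlorophenyl versions of the shared core.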